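Alkyne-Uracil Phthalimides: Geometry of the Butenyl Linker

The source may hold more compounds than are shown below. What is called first, only, known or untested is meant among the compounds shown, and "the series" means these compounds.

Of the compounds shown here, two have been measured in an ADME assay on WI-38 cells (Homo sapiens) for cytotoxicity, read by MTT assay, with a stated time of 3 days; a lower number here means a stronger inhibitor, a higher number a weaker inhibitor. Compound 1, `CCCCCCCCC#Cc1cn(C/C=C/CN2C(=O)c3ccccc3C2=O)c(=O)[nH]c1=O`, gives 53000 nM. Compound 2, `CCCCC#Cc1cn(C/C=C\CN2C(=O)c3ccccc3C2=O)c(=O)[nH]c1=O`, gives 28000 nM. Among the measured compounds shown here, compound 2 holds the lower of the two numbers, and its only comparison is to compound 1, whose number is higher by an amount that stays inside the usual scatter; no order between the two can be read from this.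

Compound 3, `CCCCC#Cc1cn(C/C=C/CN2C(=O)c3ccccc3C2=O)c(=O)[nH]c1=O`, has not yet been measured. From compound 2 it differs as follows: the two compounds have the same atoms and bonds and differ only in configuration as drawn: 1 of 1 stereo elements differ; a double bond is drawn Z in compound 2 and E in compound 3. For the measured compounds named here, no step between measured compounds isolates this change. Compound 1 carries the E geometry together with a longer alkyne chain, and its number does not separate from that of compound 2, so a step of no size beyond the scatter is expected in either direction. For compound 3 the expected value in this assay is 35000 nM, within 15000 nM to 90000 nM. The implied step, a 1.3-fold higher number from compound 2 to compound 3 (0.10 log units; within the scatter), is estimated to be small.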

Compound 3, half-maximal inhibitory concentration: 35000 nM
Estimate against measurement, compound 3: no gap at the digits printed; low and high end bracket the measured number.
By their numbers in this assay, from the lowest: compounds 2, 3 and 1 (each within the scatter of the next).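

In this assay, the geometry of the linker double bond now has a direct reading, a 1.3-fold higher number from compound 2 to compound 3 (0.10 log units; within the scatter), and Z and E are not separated at this position. The alkyne chain also has its own reading: hydrogen in place of butyl on a saturated chain carbon, four bonds along the chain from a triple-bonded carbon, gives a 1.5-fold lower number from compound 1 to compound 3 (0.18 log units; within the scatter), and this change is not separated either. The geometry reading involves no other structural variable: the fact that compounds 2 and 3 differ only in the configuration as drawn

On these data alone, whether any change on the shared core can move the number beyond the scatter remains open, as all three compounds lie within it. A terminal amine or carboxylic acid on the alkyne chain, or a chain longer than that of compound 1, would test this further.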